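This account rests on a few compounds, and the source may have more. Where it says the series, first, only, none or still open, it means among the compounds named here.

Measured so far:
compound 1, `Cn1cc(-c2cc(C(O)(C(F)(F)F)C(F)(F)F)cnc2N2CCN(S(=O)(=O)c3ccc(N)nc3)CC2)cn1`: 19 mL.min-1.g-1
compound 2, `CC(C)n1cc(-c2cc(C(O)(C(F)(F)F)C(F)(F)F)cnc2N2CCN(S(=O)(=O)c3ccc(N)nc3)CC2)cn1`: 38 mL.min-1.g-1
compound 3, `CC(C)(C)n1cc(-c2cc(C(O)(C(F)(F)F)C(F)(F)F)cnc2N2CCN(S(=O)(=O)c3ccc(N)nc3)CC2)cn1`: 86 mL.min-1.g-1

In an ADME assay (liver) for metabolic stability, with Liver microsome (Homo sapiens) as the target, using microsomes and NADPH, with a stated time of 30 min, tested at 1 uM (a lower number here means slower removal, a higher number faster removal of the compound), compound 1 gives the lowest of the three numbers. Its nearest neighbour is compound 2, with a 2.0-fold higher number from compound 1 to compound 2 (0.30 log units; within the scatter), and the furthest is compound 3, with a 4.5-fold higher number from compound 1 to compound 3 (0.66 log units; beyond the scatter); between them stands a 2.3-fold higher number from compound 2 to compound 3 (0.35 log units; beyond the scatter). Compound 4, `NC(=O)c1cccc(-c2cc(C(O)(C(F)(F)F)C(F)(F)F)cnc2N2CCN(S(=O)(=O)c3ccc(N)nc3)CC2)c1`, differs from compound 1 by 3-carbamoylphenyl in place of 1-methyl-1H-pyrazol-4-yl on an aromatic carbon. The measured steps all concern growth of the alkyl group on the aromatic nitrogen of the ring that now leaves, so they bear on this change only loosely; they show that larger substituents at this position gave higher numbers in this assay. For compound 4 a step of a 1.3-fold higher number from compound 1 to compound 4 (0.12 log units; within the scatter) is expected, at most modest, so compound 4 is estimated at 25 mL.min-1.g-1 with a range of 10 mL.min-1.g-1 to 60 mL.min-1.g-1.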

Compound 4, intrinsic clearance in microsomes: 17 mL.min-1.g-1
For compound 4 the middle estimate is 1.5-fold (0.17 log units) above the measured one; measured number inside the range.
By their numbers in this assay, from the lowest: compounds 4, 1 and 2 (each within the scatter of the next, the first and the last beyond it); then compound 3.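

In this assay, swapping 1-methyl-1H-pyrazol-4-yl for the larger 3-carbamoylphenyl gives a 1.1-fold lower number from compound 1 to compound 4 (0.05 log units; within the scatter) and so leaves the number unmoved. Size at this position therefore does not by itself go with a higher number, as the alkyl series alone suggested: the larger 3-carbamoylphenyl group still gives a 2.2-fold lower number from compound 2 to compound 4 (0.35 log units; beyond the scatter) and a 5.1-fold lower number from compound 3 to compound 4 (0.70 log units; beyond the scatter). No evidence at hand explains this result. The compounds shown leave open whether the carbamoyl group or the phenyl ring sets this number, and how a nitrile or a carboxylic acid in place of the carbamoyl group would read.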